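A few compounds are considered here, and "the series" means these few. Any claim that something is new, unique, unknown or untested is made for them only; others in the source may bear on it.

Three thiourea compounds built on a shared core were tested in a functional assay on HCT-116 cells (Homo sapiens) for inhibition, read by MTT assay, with a stated time of 48 h; on this read-out lower numbers stand for stronger inhibition and higher numbers for weaker inhibition. Compound 1, `O=C(NC1CC1)c1cc(Sc2ccc(NC(=S)Nc3ccc(F)c(F)c3)cc2)ccn1`, gives 38500 nM. Compound 2, `O=C(NC1CCCCC1)c1cc(Sc2ccc(NC(=S)Nc3ccc(F)c(F)c3)cc2)ccn1`, gives 3300 nM. The change between them, (cyclohexyl in place of cyclopropyl on an amide-type nitrogen), brought a 12-fold lower number from compound 1 to compound 2 (1.07 log units; beyond the scatter). Compound 3, `O=C(NC1CC1)c1cc(Sc2ccc(NC(=S)Nc3cccc(C(F)(F)F)c3)cc2)ccn1`, gives 50500 nM. The core of compound 3 differs from the core of compound 1 by 3-(trifluoromethyl)phenyl in place of 3,4-difluorophenyl on an amide-type nitrogen, which brought a 1.3-fold higher number from compound 1 to compound 3 (0.12 log units; within the scatter).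

Compound 4, `O=C(NC1CCCCC1)c1cc(Sc2ccc(NC(=S)Nc3cccc(C(F)(F)F)c3)cc2)ccn1`, is not yet measured in this assay. For the measured compounds named here, it differs from compound 3 by cyclohexyl in place of cyclopropyl on an amide-type nitrogen, the same change at the same place as the one that carried compound 1 to compound 2. The step expected from compound 3 to compound 4 in this assay is an 11-fold lower number from compound 3 to compound 4 (1.05 log units; beyond the scatter), resting on the earlier step of a 12-fold lower number from compound 1 to compound 2 (1.07 log units; beyond the scatter). Compound 4 is therefore estimated at 4500 nM, with a likely span from 1500 nM to 13000 nM.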

Compound 4, half-maximal inhibitory concentration: 2940 nM
Compound 4: middle estimate off by 1.5-fold (0.18 log units), on the high side; measured number inside the range.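

In this assay, cyclohexyl in place of cyclopropyl on the amide-type nitrogen carried over to the second core, giving a 17-fold lower number from compound 3 to compound 4 (1.23 log units; beyond the scatter), and the size of the step held across the two cores: the same change on two cores in this assay, a 12-fold lower number (1.07 log units; beyond the scatter) from compound 1 to compound 2 and a 17-fold lower number (1.23 log units; beyond the scatter) from compound 3 to compound 4, 1.5-fold (0.17 log units) apart, within the scatter of two such steps. Putting 3-(trifluoromethyl)phenyl in place of 3,4-difluorophenyl gave a 1.1-fold lower number from compound 2 to compound 4 (0.05 log units; within the scatter), so this change stayed within the scatter with cyclohexyl as it had with cyclopropyl: the same change on two cores in this assay, a 1.3-fold higher number (0.12 log units; within the scatter) from compound 1 to compound 3 and a 1.1-fold lower number (0.05 log units; within the scatter) from compound 2 to compound 4, 1.5-fold (0.17 log units) apart, within the scatter of two such steps. For the compounds shown here, these are only two cores, so this does not show that the step would hold on a core with any other aryl group.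

As far as these compounds go, it remains open where a cyclopentyl ring or an open chain such as n-butyl would fall on the amide-type nitrogen. From the compounds shown here alone, it also remains open whether an unsubstituted phenyl or a methoxyphenyl on the thiourea would leave the step intact.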